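Amide substituent change on a quinoline-type series of B-cell inhibitors

This account rests on a few compounds, and the source may have more. Where it says the series, first, only, none or still open, it means among the compounds named here.

Measured so far:
compound 1 `C[C@H](Nc1ncnc(N)c1C#N)c1nc2ccc(F)cc2c(-c2ccccn2)c1-c1ccccn1`: 4.6 nM
compound 2 `C[C@H](Nc1ncnc(N)c1C#N)c1nc2ccc(F)cc2c(C(=O)N(C)C)c1-c1ccccc1`: 2.2 nM

In a functional assay on cells (B cell, Homo sapiens) for inhibition, read by thymidine incorporation, with stated times of 30 min and 72 h (on this read-out lower numbers stand for stronger inhibition and higher numbers for weaker inhibition), compound 2 gives 2.2 nM, the lowest of the two numbers recorded. Its nearest neighbour is compound 1, which in this assay gives 4.6 nM, a higher number and a gap beyond the scatter of this read-out. Among the measured compounds shown here, the two compounds differ in more than one place, so no single step between them can be read.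

Compound 3 `CC(C)NC(=O)c1c(-c2ccccc2)c([C@H](C)Nc2ncnc(N)c2C#N)nc2ccc(F)cc12` has not yet been measured in this assay. Relative to compound 2 the change is isopropylamino in place of dimethylamino on a carbonyl carbon. Nothing in the measured pair speaks to this exchange, so the expected step is small, in either direction or none beyond the scatter. The step that this estimate means, a 1.6-fold higher number from compound 2 to compound 3 (0.20 log units; within the scatter), is expected to be slight. For compound 3 in this assay the estimated value is 3.5 nM, with a range from 1.2 nM to 10 nM.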

Compound 3, half-maximal inhibitory concentration: 1.3 nM
Beside the measured number, compound 3's estimate is 2.7-fold (0.43 log units) above it, within the range that was stated.
By their numbers in this assay, from the lowest: compounds 3 and 2 (each within the scatter of the next); then compound 1.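

In this assay, among the compounds shown here, the exchange of dimethylamino for isopropylamino on a carbonyl carbon gives a 1.7-fold lower number from compound 2 to compound 3 (0.23 log units; within the scatter), the first step that can be read at this place; steps involving compound 1 cannot be read, as it differs from the others in more than one place. This carbonyl carbon therefore takes either group with no change beyond the scatter, even though the isopropylamino group brings an amide hydrogen that dimethylamino lacks. No available data explain how the two amides compare.

The contributions of the amide hydrogen and the added carbon cannot be separated, since both enter in the same step. Also open, from the compounds shown here alone, is how this read-out responds at the same carbonyl carbon to a plain amino group, a longer chain such as n-butylamino, or a morpholine ring.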